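A few compounds are considered here, and "the series" means these few. Any claim that something is new, unique, unknown or untested is made for them only; others in the source may bear on it.

Compound 2 `CCNC(=O)c1ccc(-c2nnc(C3(c4ccc(Cl)cc4)CCC3)n2C)cc1` is known in an assay on isolated protein for inhibition of 11-beta-hydroxysteroid dehydrogenase type 2 (Mus musculus) (on this read-out lower numbers stand for stronger inhibition and higher numbers for weaker inhibition), only as a limit, > 4000 nM. Among the compounds with values here, its one measured neighbour, compound 1 `Cn1c(-c2ccc(-c3cncnc3)cc2)nnc1C1(c2ccc(Cl)cc2)CCC1`, is likewise known in this assay only as a limit, > 4000 nM. The step that the two limits leave unreadable from compound 1 to compound 2 therefore cannot be read, since (the limit of > 4000 nM in this assay, at which 2 of the 2 values shown sit). Compound 3 `Cc1noc(C)c1-c1ccc(-c2nnc(C3(c4ccc(Cl)cc4)CCC3)n2C)cc1` differs from compound 2 by 3,5-dimethyl-1,2-oxazol-4-yl in place of ethylcarbamoyl on an aromatic carbon. Within the data shown here, no measured step bears on this change, and both known values sit at the limit, so no step beyond the scatter is expected in this assay, with a step that the limit leaves unreadable from compound 2 to compound 3 as the expected size. Compound 3 is estimated at 6000 nM, within 2000 nM to 20000 nM, most probably again reported only as a limit.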

Compound 3, half-maximal inhibitory concentration: > 4000 nM
Compound 3 gave a limit, no number; the forecaster's own chance of this, stated with the estimate: 75%; the middle value is on the limit's open side.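

Compound 1, compound 2 and compound 3 are all known in this assay only as limits, so no step among them can be read: the limit of > 4000 nM in this assay, at which 3 of the 3 values shown sit.

The compounds shown leave open whether swapping these groups changes inhibition in this assay at all.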